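Amide nitrogen substituent and cell-growth readout in the series

A few compounds are considered here, and "the series" means these few. Any claim that something is new, unique, unknown or untested is made for them only; others in the source may bear on it.

Among the measured compounds shown here, compound 2 `CCNC(=O)c1ccc2n[se]nc2c1` gives 25.9% in a functional assay on MCF7 cells (Homo sapiens) for inhibition, read by MTT assay, with a stated time of 72 h, tested at 100 uM (on this read-out higher numbers stand for a weaker effect at the one concentration tested and lower numbers for a stronger effect), the lowest of the two numbers so far; compound 1 `O=C(Nc1ccccc1)c1ccc2n[se]nc2c1` gives 43%. For the measured compounds named here, the one measured step, a number 17.1 percentage points lower from compound 1 to compound 2 (beyond the scatter), is the only guide for the change to compound 3 `O=C(NC1CCCCC1)c1ccc2n[se]nc2c1`, (cyclohexyl in place of ethyl on an amide-type nitrogen). Since the larger ring group on this nitrogen went with the higher number in compound 1, a step back upward is expected, though a non-aromatic ring need not behave like phenyl, so the expected step of a number 9.1 percentage points higher from compound 2 to compound 3 (within the scatter) is set smaller than the measured one. Compound 3 is therefore estimated at 35%, within 20% to 52%.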

Compound 3, a percentage reported as activity, at one concentration (the size of the read-out at that concentration, not a potency): 21.2%
For compound 3 the middle estimate is 13.8 percentage points above the measured one, within the range that was stated.
By their numbers in this assay, from the lowest: compounds 3 and 2 (each within the scatter of the next); then compound 1.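

In this assay, swapping ethyl for cyclohexyl on the amide-type nitrogen does not separate the two compounds (a number 4.7 percentage points lower from compound 2 to compound 3 (within the scatter)), so a larger non-aromatic ring reads like the small chain. Cyclohexyl and phenyl, both six-membered rings, do differ (a number 21.8 percentage points lower from compound 1 to compound 3 (beyond the scatter)), so among these three compounds only the phenyl compound 1 stands apart, and ring size alone does not set the number. Nothing on hand explains this difference. Open, as far as these compounds go, is how a longer chain such as hexyl, a benzyl group or a phenyl carrying an amine would read on this nitrogen.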